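Chloro in Place of Trifluoromethyl: What to Expect

The compounds below may be only part of what the source reports. "The series", "measured", "known", "first", "only" and "open" are said of these compounds alone.

Compound 2 `COc1cc2cc(Oc3ccc(NC(=O)Nc4ccc(Cl)c(C(F)(F)F)c4)cc3)c(C)nc2cc1OC` was tested in a functional assay on NCI-H226 cells (Homo sapiens) for inhibition, read by sulforhodamine B assay, with a stated time of 48 h (a lower number here means a stronger inhibitor of growth, a higher number a weaker inhibitor of growth), where compound 2 gives 1270 nM. For the measured compounds named here, only one other compound has a number here: compound 1 `COc1cc2cc(Oc3ccc(NC(=O)Nc4cccc(C(F)(F)F)c4)cc3)c(C)nc2cc1OC`, which in this assay gives 1800 nM. The two differ by a single change, chloro in place of hydrogen on an aromatic carbon, and the step of a 1.4-fold lower number from compound 1 to compound 2 (0.15 log units; within the scatter) lies within the scatter. Compound 2 thus stands among two numbers that sit within the scatter of each other, so neither compound can be called the stronger.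

Compound 3 `COc1cc2cc(Oc3ccc(NC(=O)Nc4ccc(Cl)c(Cl)c4)cc3)c(C)nc2cc1OC` is the next step: chloro in place of trifluoromethyl on an aromatic carbon. Going by the values given here, no measured step covers this kind of exchange; the only measured step concerns a different change and lay within the scatter. The step from compound 2 to compound 3 in this assay is therefore expected to be a 1.2-fold higher number from compound 2 to compound 3 (0.07 log units; within the scatter), with no clear direction. Compound 3 is expected to give 1500 nM, within a range from 600 nM to 4000 nM.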

Compound 3, concentration for 50% growth inhibition: 3120 nM
Compound 3: middle estimate off by 2.1-fold (0.32 log units), on the low side, within the range that was stated.
By their numbers in this assay, from the lowest: compounds 2, 1 and 3 (each within the scatter of the next, the first and the last beyond it).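

For the compounds shown here, at this position, on an aromatic carbon ortho to a chloro group, trifluoromethyl and chloro are not interchangeable in this assay: the exchange brings a modest but real loss (a 2.5-fold higher number from compound 2 to compound 3 (0.39 log units; beyond the scatter)), the only step in this small set that passes the scatter. The wider replacement of 3-(trifluoromethyl)phenyl by 3,4-dichlorophenyl (a 1.7-fold higher number from compound 1 to compound 3 (0.24 log units; within the scatter)) stays inside the scatter, so the difference appears only when compound 3 is set against compound 2, the compound that carries both groups. Nothing available explains why the two groups differ here.

As far as these compounds go, whether a methyl, a methoxy or a bromo group at this carbon would track trifluoromethyl or chloro remains open. So does the effect of an amine there, a group quite unlike either.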